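The source may hold more compounds than are shown below. What is called first, only, known or untested is meant among the compounds shown, and "the series" means these compounds.

Series read out in an ADME assay for pharmacokinetics; a higher number here means that the compound lasts longer, a lower number that the compound disappears faster.

Measured so far:
compound 1, `CC(=O)CCC(=O)Nc1ccc2c(Cl)c(OCCSC(=N)N)oc(=O)c2c1`: 0.467 h
compound 2, `C[C@H](NC(=O)OC(C)(C)C)C(=O)N[C@@H](C)C(=O)Nc1ccc2c(Cl)c(OCCSC(=N)N)oc(=O)c2c1`: 0.667 h
compound 3, `N=C(N)SCCCOc1oc(=O)c2cc(N)ccc2c1Cl`: 1.5 h

Compound 1 holds the lowest of the three numbers. Its nearest neighbour is compound 2, whose value lies within the usual scatter of this assay, so no order between compound 1 and compound 2 can be read from these two numbers. Compound 3 is furthest from compound 1, and that gap lies beyond the scatter. The three measured values together lie close to one another.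

Compound 4, `C[C@H](NC(=O)Nc1ccc2c(Cl)c(OCCSC(=N)N)oc(=O)c2c1)c1ccccc1`, has not yet been measured in this assay. It differs from compound 1 in one place:
(1-phenylethyl)amino in place of 2-acetylethyl on a carbonyl carbon

For the measured compounds named here, no pair of measured compounds differs in only this place, so no measured step can be carried over. Given the narrow span of the three measured values, the step from compound 1 to compound 4 is expected to be small and upward, of a size not clearly beyond the scatter, a 1.5-fold higher number from compound 1 to compound 4 (0.18 log units; within the scatter). Compound 4 is accordingly estimated at 0.7 h, with a range from 0.3 h to 1.6 h.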

Compound 4, half-life: 0.933 h
Compound 4: middle estimate off by 1.3-fold (0.12 log units), on the low side; the range from low to high includes it.
By their numbers in this assay, from the lowest: compounds 1, 2, 4 and 3 (each within the scatter of the next, the first and the last beyond it).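

On the carbonyl carbon, in this assay, (1-phenylethyl)amino in place of 2-acetylethyl gives a step (a 2.0-fold higher number from compound 1 to compound 4 (0.30 log units; within the scatter)) that stays within the scatter, so the two compounds cannot be ordered. For the compounds shown here, this is the first single-place comparison, and it shows that this place accepts a larger group with an aromatic ring, a hydrogen-bond donor and a defined stereocentre, with no step beyond the scatter for this one pair. Nothing available explains the size of this step.

The compounds shown leave open whether a different group on this carbonyl carbon, such as morpholine, benzylamino or a longer chain ending in a carboxylic acid, would give a step beyond the scatter. They also do not separate the contributions of the phenyl ring, the methyl branch and the stereocentre within (1-phenylethyl)amino.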